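This account rests on a few compounds, and the source may have more. Where it says the series, first, only, none or still open, it means among the compounds named here.

Of the compounds shown here, three on a shared core have been measured so far. Compound 1 `NS(=O)(=O)c1cccc(-c2nc(C(c3ccc(F)cc3)c3ccc(F)cc3)sc2CC(=O)O)c1` gives 140 nM in an in vitro assay on HEK385-7 cells for displacement of a labelled ligand from prostaglandin D2 receptor 2 (Homo sapiens); on this read-out lower numbers stand for stronger inhibition and higher numbers for weaker inhibition. Compound 2 `O=C(O)Cc1sc(C(c2ccc(F)cc2)c2ccc(F)cc2)nc1-c1ccoc1` gives 14 nM in this assay, and compound 3 `O=C(O)Cc1sc(C(c2ccc(F)cc2)c2ccc(F)cc2)nc1-c1ccncc1` gives 5.3 nM. Each measured change swaps the aromatic group attached to the core: a 10-fold lower number from compound 1 to compound 2 (1.00 log units; beyond the scatter); a 26-fold lower number from compound 1 to compound 3 (1.42 log units; beyond the scatter); a 2.6-fold lower number from compound 2 to compound 3 (0.42 log units; beyond the scatter). Compound 3 therefore holds the lowest number of the three, with compound 2 nearest and compound 1 furthest.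

Compound 4 `CN(C)c1cc(-c2nc(C(c3ccc(F)cc3)c3ccc(F)cc3)sc2CC(=O)O)ccn1` is not yet measured. It differs from compound 3 by dimethylamino in place of hydrogen on an aromatic carbon, which read one bond further out is pyridin-4-yl to 2-(dimethylamino)pyridin-4-yl. Among the compounds with values here, none of the measured steps adds a group onto the pyridine; all three exchange one aromatic ring for another, so they bear only loosely on this change and give no direction for it. No step beyond the scatter is therefore expected in this assay either way, though the uncertainty is wide. For compound 4 a value of 5 nM is estimated, between 1.5 nM and 20 nM, corresponding to an expected step of a 1.1-fold lower number from compound 3 to compound 4 (0.03 log units; within the scatter).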

Compound 4, half-maximal inhibitory concentration: 380 nM
Compound 4: the middle estimate sits 76-fold (1.88 log units) below what was measured; measured number outside the range, above it.
By their numbers in this assay, from the lowest: compound 3; then compound 2; then compound 1; then compound 4.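

Dimethylamino in place of hydrogen, next to the ring nitrogen, gives a 72-fold higher number from compound 3 to compound 4 (1.86 log units; beyond the scatter) in this assay, so a single addition to the pyridin-4-yl group of compound 3 outweighs any ring exchange seen earlier. The 2-(dimethylamino)pyridin-4-yl group also loses against both other aromatic groups, with a 27-fold higher number from compound 2 to compound 4 (1.43 log units; beyond the scatter) and a 2.7-fold higher number from compound 1 to compound 4 (0.43 log units; beyond the scatter) on the same core, which places it behind even the 3-sulfamoylphenyl group. Nothing available here accounts for the size of this step.

Going by these compounds, it remains open whether the loss belongs to dimethylamino specifically or to any group at this place on the pyridine. An amino, methylamino or methoxy group at the same carbon would separate these readings, and a methyl group on another ring carbon would show whether the effect is tied to this place.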